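Adding Two Fluorines to the Benzyl Group of a Coumarin Amine

The source may report more compounds than this note shows. Statements on the series, on what has been measured and on what is new or still open speak of the compounds shown alone.

Measured so far:
- compound 1, `C#CCN(CCCCOc1ccc2ccc(=O)oc2c1)Cc1ccc(C)cc1`, gives 94500 nM in an ADME assay on isolated protein for inhibition of Amine oxidase [flavin-containing] A (Homo sapiens), read by fluorescence and Amplex Red, with stated times of 15 min and 20 min; on this read-out lower numbers stand for stronger inhibition and higher numbers for weaker inhibition
- compound 2, `C#CCN(CCCCOc1ccc2ccc(=O)oc2c1)Cc1ccccc1`, gives 89400 nM in this assay

Compound 2 holds the lowest of the two numbers, but its nearest neighbour, compound 1, sits within the scatter, so the two compounds cannot be told apart on this assay. For the measured compounds named here, the only measured step, a 1.1-fold lower number from compound 1 to compound 2 (0.02 log units; within the scatter), is itself within the scatter.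

Compound 3, `C#CCN(CCCCOc1ccc2ccc(=O)oc2c1)Cc1ccc(F)c(F)c1`, differs from compound 2 by 3,4-difluorophenyl in place of phenyl on a saturated chain carbon bound to an amine nitrogen. Going by the values given here, no measured step touches a fluorine on this ring, so the expectation rests on the general observation that the one change made so far on this ring left this assay unmoved. The step from compound 2 to compound 3 is therefore expected to be a 1.1-fold lower number from compound 2 to compound 3 (0.02 log units; within the scatter), which lies within the scatter. Compound 3 is estimated at 85000 nM, with a range from 40000 nM to 180000 nM.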

Compound 3, half-maximal inhibitory concentration: 93200 nM
Beside the measured number, compound 3's estimate is 1.1-fold (0.04 log units) below it; low and high end bracket the measured number.
By their numbers in this assay, from the lowest: compounds 2, 3 and 1 (each within the scatter of the next).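

Placing 3,4-difluorophenyl in place of phenyl gives a 1.0-fold higher number from compound 2 to compound 3 (0.02 log units; within the scatter) in this assay and lies within the scatter, while the same ring in place of 4-methylphenyl gives a 1.0-fold lower number from compound 1 to compound 3 (0.01 log units; within the scatter) and also lies within the scatter. Compound 1, compound 2 and compound 3 therefore cannot be told apart on this read-out, so at this position neither the methyl group nor the two fluorines produce a difference that can be read. Nothing available here offers an explanation for this result.

On these data alone, it remains open whether a carboxylic acid or an amine on this ring, or a longer chain on the amine nitrogen in place of the benzyl group, would separate from these three compounds. Also open, as far as these compounds go, is whether these ring changes matter on any other read-out.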